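The source may hold more compounds than are shown below. What is called first, only, known or untested is meant among the compounds shown, and "the series" means these compounds.

Measured compounds in an ADME assay on the whole organism for pharmacokinetics, with Rattus norvegicus as the target, at a dose of 3 mg/kg by the oral route; a higher number here means more compound in the circulation at the dose given, a lower number less compound in the circulation:
- compound 1 `COC(=O)N[C@H](C(=O)N1CCC[C@H]1C(=O)Nc1ccc([C@H]2CC[C@H](c3ccc(NC(=O)[C@@H]4CCCN4C(=O)[C@@H](NC(=O)OC)C(C)C)cc3)N2c2ccc(C(F)(F)F)cc2)cc1)C(C)C`: compound 1 gives 221 nM
- compound 2 `COC(=O)N[C@H](C(=O)N1CCC[C@H]1C(=O)Nc1ccc([C@@H]2CC[C@@H](c3ccc(NC(=O)[C@@H]4CCCN4C(=O)[C@@H](NC(=O)OC)C(C)C)cc3)N2c2ccc(C(F)(F)F)cc2)cc1)C(C)C`: compound 2 gives 33.1 nM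
- compound 3 `COC(=O)N[C@H](C(=O)N1CCC[C@H]1C(=O)Nc1ccc([C@@H]2CC[C@@H](c3ccc(NC(=O)[C@@H]4CCCN4C(=O)[C@@H](NC(=O)OC)C(C)C)cc3)N2c2ccc(F)cc2)cc1)C(C)C`: compound 3 gives 222 nM

Compound 3 stands highest of the three numbers, though its gap to compound 1 lies within the scatter; compound 2 sits well below it, a 6.7-fold higher number from compound 2 to compound 3 (0.83 log units; beyond the scatter).

Compound 4 `COC(=O)N[C@H](C(=O)N1CCC[C@H]1C(=O)Nc1ccc([C@H]2CC[C@H](c3ccc(NC(=O)[C@@H]4CCCN4C(=O)[C@@H](NC(=O)OC)C(C)C)cc3)N2c2ccc(F)cc2)cc1)C(C)C` differs from compound 3 as follows: the two compounds have the same atoms and bonds and differ only in configuration as drawn: 2 of 6 stereo elements differ; a stereocentre at a saturated ring carbon is drawn S in compound 3 and R in compound 4; a stereocentre at a saturated ring carbon is drawn S in compound 3 and R in compound 4. Among the measured compounds shown here, the one measured step that bears on this is a 6.7-fold lower number from compound 1 to compound 2 (0.82 log units; beyond the scatter), a modest drop that rests on (the fact that compounds 1 and 2 differ only in the configuration as drawn). There the two saturated ring carbons went from R to S; here they go from S to R, so the step from compound 3 to compound 4 is expected to run upward in this assay, by roughly the same modest size. Compound 4 carries the ring configuration of compound 1, while compound 3 carries that of compound 2. Compound 1 gives 221 nM, and compound 3 gives 222 nM, so full additivity would put compound 4 above every measured number; the estimate is set a little short of that.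

For compound 4 the expected value is 800 nM, with a range of 250 nM to 2500 nM. This estimate implies an expected step of a 3.6-fold higher number from compound 3 to compound 4 (0.56 log units; beyond the scatter).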

Compound 4, maximal plasma concentration in the Rattus norvegicus assay: 1610 nM
Estimate against measurement, compound 4: 2.0-fold (0.30 log units) below; the range from low to high includes it.
By their numbers in the Rattus norvegicus assay, from the lowest: compound 2; then compounds 1 and 3 (each within the scatter of the next); then compound 4.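

In the Rattus norvegicus assay the configuration change now reads on two substituents, with a 7.3-fold higher number from compound 3 to compound 4 (0.86 log units; beyond the scatter) for fluoro and a 6.7-fold lower number from compound 1 to compound 2 (0.82 log units; beyond the scatter) in the opposite direction for trifluoromethyl. Fluoro in place of trifluoromethyl also gives a 7.3-fold higher number from compound 1 to compound 4 (0.86 log units; beyond the scatter), so the substituent change holds in both configurations and the two changes behave as additive across these four compounds: the same change on two cores in the Rattus norvegicus assay, a 6.7-fold higher number (0.83 log units; beyond the scatter) from compound 2 to compound 3 and a 7.3-fold higher number (0.86 log units; beyond the scatter) from compound 1 to compound 4, 1.1-fold (0.04 log units) apart, within the scatter of two such steps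

In a physicochemical assay for lipophilicity, read by HPLC, at pH 7.4 (a higher number here means a more lipophilic compound, a lower number a more polar compound), compound 3 gives 4.6 and compound 4 gives 4.6, with no change at the digits printed from compound 3 to compound 4 (within the scatter), so the configuration step in the Rattus norvegicus assay comes without a shift in distribution coefficient.

On these data alone, the two saturated ring stereocentres change only together here, so the share of each one stays open. As far as these compounds go, whether the same ordering holds with a nitrile or a methoxy group on that aromatic carbon also stays open.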